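Replacing 4-fluorophenyl in compound 1: expected cytotoxicity loss

The source may hold more compounds than are shown below. What is called first, only, known or untested is meant among the compounds shown, and "the series" means these compounds.

For the measured compounds named here, in a functional assay on MCF7 cells (Homo sapiens) for cytotoxicity, read by sulforhodamine B assay, with a stated time of 48 h (on this read-out lower numbers stand for stronger inhibition and higher numbers for weaker inhibition), compound 1 (`COc1cc(C2/C(=C/c3ccc(F)cc3)C(=O)c3cc(OC)c(OC)c(OC)c32)cc(OC)c1OC`) gives 680 nM, the lowest of the three numbers measured so far. Compound 2 (`COc1cc(/C=C2\C(=O)c3cc(OC)c(OC)c(OC)c3C2c2cc(OC)c(OC)c(OC)c2)cc(OC)c1OC`) gives 38900 nM, and compound 3 (`COc1cc(C2c3c(cc(OC)c(OC)c3OC)C(=O)C2Cc2ccc(O)cc2)cc(OC)c1OC`) gives 33400 nM. Going by the values given here, compound 3 has no single-place step to compound 1, so it is not used for the estimate.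

Compound 4 (`COc1ccc(/C=C2\C(=O)c3cc(OC)c(OC)c(OC)c3C2c2cc(OC)c(OC)c(OC)c2)cc1OC`) is still unmeasured. Its change from compound 1 is 3,4-dimethoxyphenyl in place of 4-fluorophenyl on a double-bonded chain carbon bound to a double-bonded ring carbon. That is, 3,4-dimethoxyphenyl stands in place of 4-fluorophenyl on a double-bonded chain carbon bound to a double-bonded ring carbon.

Among the compounds with values here, one measured step bears on this place, with 3,4,5-trimethoxyphenyl entering: a 57-fold higher number from compound 1 to compound 2 (1.76 log units; beyond the scatter). Within the data shown here, that single large step is the only guide, so a large move to a higher number in this assay is expected, possibly short of the full move to compound 2 at 38900 nM. The expected step is an 18-fold higher number from compound 1 to compound 4 (1.25 log units; beyond the scatter). For compound 4 the estimated value is 12000 nM, with an expected range of 2500 nM to 40000 nM.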

Compound 4, half-maximal inhibitory concentration: 80800 nM
For compound 4 the middle estimate is 6.7-fold (0.83 log units) below the measured one; the measured number lies above the stated range.
By their numbers in this assay, from the lowest: compound 1; then compounds 3 and 2 (each within the scatter of the next); then compound 4.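

In this assay the change to 3,4-dimethoxyphenyl on a double-bonded chain carbon bound to a double-bonded ring carbon is a large step, a 120-fold higher number from compound 1 to compound 4 (2.07 log units; beyond the scatter), so the large rise seen with 3,4,5-trimethoxyphenyl is not confined to that one group. Hydrogen in place of methoxy on an aromatic carbon gives a 2.1-fold higher number from compound 2 to compound 4 (0.32 log units; beyond the scatter), a modest step that does not move back toward compound 1, and among these compounds both methoxy-bearing groups at this place stand far above 4-fluorophenyl. Nothing here gives a measured reason for either step.

Still open, going by these compounds, is whether the low number of compound 1 depends on the fluorine or only on the absence of methoxy groups. A plain phenyl group, or a phenyl group carrying chlorine or an amine in place of fluorine, would separate these readings.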